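The source may hold more compounds than are shown below. What is called first, only, known or untested is meant among the compounds shown, and "the series" means these compounds.

Series notes, cytotoxicity. Of the compounds shown here, three carry the shared core and have been measured in an ADME assay on MT2 cells (Homo sapiens) for cytotoxicity, read by XTT assay, with a stated time of 4 days; a lower number here means that less compound is tolerated, a higher number that more compound is tolerated. Compound 1 `Cc1ccc(-c2c3c(nc(C)c2[C@H](OC(C)(C)C)C(=O)O)CCN(c2ccc(-c4ccccc4)cc2)C3)cc1` returns only a limit of the assay in this assay, at > 40000 nM. Compound 2 `Cc1ccc(-c2c3c(nc(C)c2C(OC(C)(C)C)C(=O)O)CCN(Cc2ccccc2-c2ccccc2)C3)cc1` likewise sits at the limit, giving > 40000 nM in this assay. Compound 3 `Cc1ccc(CCCN2CCc3nc(C)c([C@H](OC(C)(C)C)C(=O)O)c(-c4cc(F)c5c(c4C)CCCO5)c3C2)cc1F` also reaches only the limit, with > 40000 nM. So compound 1 stands where every measured member stands: no number, only (the limit of > 40000 nM in this assay, at which 3 of the 3 values shown sit). For the measured compounds named here, no step between measured compounds can be drawn here, since none differ in a single place.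

Compound 4 `Cc1ccc(-c2c3c(nc(C)c2[C@H](OC(C)(C)C)C(=O)O)CCN(C(=O)NCc2ccccc2)C3)cc1` is the next candidate for this assay. Its change from compound 1 is benzylcarbamoyl in place of 4-phenylphenyl on an amine nitrogen in a ring. With every measured member sitting at the limit, no direction of change can be read from the data; the step from compound 1 to compound 4 is expected to be none beyond the scatter, most likely ending again at the limit, a step that the limit leaves unreadable from compound 1 to compound 4. Compound 4 is therefore estimated at 60000 nM in this assay, within 20000 nM to 150000 nM.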

Compound 4, half-maximal cytotoxic concentration: > 40000 nM
Compound 4 ended at the assay's limit (the forecaster's own chance of this, stated with the estimate: 85%); the middle value does not contradict the limit.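

No step can be read from compound 1 to compound 4 in this assay, since both return only a limit: the limit of > 40000 nM in this assay, at which 4 of the 4 values shown sit.

The compounds shown leave open what number any of them would give in this assay, and whether benzylcarbamoyl in place of 4-phenylphenyl changes it.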